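Lengthening the chain from ethyl to propyl

The source may report more compounds than this note shows. Statements on the series, on what has been measured and on what is new or still open speak of the compounds shown alone.

Measured in a functional assay on T47D cells (Homo sapiens) for antiproliferative activity, read by MTT assay, with a stated time of 72 h; a lower number here means a stronger inhibitor, a higher number a weaker inhibitor:
Compound 1 `COc1cc(-c2nccn2C)cc(OC)c1OC`: > 100000 nM
Compound 2 `CCn1ccnc1-c1cc(OC)c(OC)c(OC)c1`: > 100000 nM

Compound 2 reads > 100000 nM, which is a limit of the assay and not a number. Compound 1 and compound 2 share (the limit of > 100000 nM in this assay, at which 2 of the 2 values shown sit). Compound 3 `CCCn1ccnc1-c1cc(OC)c(OC)c(OC)c1` carries one change: methyl in place of hydrogen on a saturated chain carbon, two bonds along the chain from an aromatic nitrogen. Among the compounds with values here, the only measured step of this kind is a step that the two limits leave unreadable from compound 1 to compound 2, so it offers no size to carry over. No step beyond the scatter is therefore expected in this assay. The expected step is a number no higher from compound 2 to compound 3 (the limit leaves the size open). For compound 3 the estimate is 100000 nM, with an expected range of 40000 nM to 250000 nM.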

Compound 3, half-maximal inhibitory concentration: > 100000 nM
Compound 3 ended at the assay's limit; the forecaster's own chance of this, stated with the estimate: 85%; the middle value lies on the limit itself.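

No step can be read among compound 1, compound 2 and compound 3 in this assay, because each value is a limit of the assay and not a number: the limit of > 100000 nM in this assay, at which 3 of the 3 values shown sit.

As far as these compounds go, whether any chain on the shared core gives a measurable inhibitory concentration stays open.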